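Replacing the Hydroxycyclohexyl Urea with a Chloropyridinyl Urea

This account rests on a few compounds, and the source may have more. Where it says the series, first, only, none or still open, it means among the compounds named here.

For the measured compounds named here, compound 3 `O=C(NC1CCC(O)CC1)N1CCC(c2nc(-c3ccc4ccccc4n3)no2)CC1` gives 2700 nM in a functional assay on Shh Light II cells (Mus musculus) for inhibition, read by a luciferase reporter (a lower number here means a stronger inhibitor, a higher number a weaker inhibitor), the highest of the three numbers so far. Compound 1 `C[C@@H]1C[C@H](c2nc(-c3ccc4ccccc4n3)no2)CCN1C(=O)Nc1ccccc1Cl` gives 2400 nM in this assay, which lies within the scatter of compound 3. Compound 2 `O=C(Nc1ccccc1Cl)N1CCN(c2nc(-c3ccc4ccccc4n3)no2)CC1` gives 140 nM in this assay, a gap to compound 3 that is well beyond the scatter.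

Compound 4 `O=C(Nc1ncccc1Cl)N1CCC(c2nc(-c3ccc4ccccc4n3)no2)CC1` differs from compound 3 in one place: 3-chloropyridin-2-yl in place of 4-hydroxycyclohexyl on an amide-type nitrogen.

Going by the values given here, no measured pair shows this exact change. Compound 4 is expected to be a stronger inhibitor than compound 3, with a step of a 6.8-fold lower number from compound 3 to compound 4 (0.83 log units; beyond the scatter), because compound 2 gives 140 nM with an aromatic urea partner on the same shared core type. Compound 4 is therefore estimated at 400 nM, within a range from 100 nM to 1600 nM.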

Compound 4, half-maximal inhibitory concentration: 2800 nM
For compound 4 the middle estimate is 7.0-fold (0.85 log units) below the measured one, outside the stated range (above it).
By their numbers in this assay, from the lowest: compound 2; then compounds 1, 3 and 4 (each within the scatter of the next).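

In this assay the swap gives a 1.0-fold higher number from compound 3 to compound 4 (0.02 log units; within the scatter), so on the shared core 3-chloropyridin-2-yl and 4-hydroxycyclohexyl on this amide-type nitrogen read alike. For the compounds shown here, this is the first single-place comparison in the set, and it shows that an aromatic ring bearing chlorine can stand in place of a non-aromatic carbon ring here with no change beyond the scatter. No available evidence bears on this result. Going by these compounds, whether an unsubstituted pyridin-2-yl or a plain cyclohexyl at this nitrogen would read apart from compound 3 and compound 4 remains open.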